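This account rests on a few compounds, and the source may have more. Where it says the series, first, only, none or still open, it means among the compounds named here.

Measured compounds:
compound 1 `COc1ccccc1C(=O)OC1CCN(C)CC1` with 1.43
compound 2 `Cc1cccc(C)c1C(=O)OC1CCN(C)CC1` with 1.27
compound 3 `CN1CCC(OC(=O)c2ccc(C(C)(C)C)cc2)CC1` with 1.13

All three share the same core and were tested in a functional assay on the whole organism with Mus musculus as the target; a higher number here means a more potent compound, by a factor of ten per unit of this negative logarithm, a lower number a less potent compound. Compound 1 gives 1.43, compound 2 gives 1.27 and compound 3 gives 1.13. Compound 3 stands at the lowest of the three numbers, but its distance to compound 2 and its distance to compound 1 both lie within the usual scatter of this assay, so the three results cannot be set in order with any confidence.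

Compound 4 `CN1CCC(OC(=O)c2ccc(F)cc2)CC1` has not yet been measured. It differs from compound 3 in one place: fluoro in place of tert-butyl on an aromatic carbon. Among the measured compounds shown here, no pair of measured compounds shows this or any other single change, so there is no measured step to lean on. The three measured compounds carry different substituents on the same ring and still sit within the scatter of one another, which speaks for a modest effect of a substituent change at that place. The step from compound 3 to compound 4 is therefore expected to be small, a number 0.07 log units higher from compound 3 to compound 4 (within the scatter), not clearly beyond the scatter in either direction. For compound 4 the estimated result in this assay is 1.2, with a range from 0.7 to 1.7.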

Compound 4, logarithm of the reciprocal of the active concentration, log(1/C): 1.38
For compound 4 the middle estimate is 0.18 log units below the measured one, within the range that was stated.
By their numbers in this assay, from the lowest: compounds 3, 2, 4 and 1 (each within the scatter of the next).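

In this assay, among the compounds shown here, the exchange of tert-butyl for fluoro on an aromatic carbon gives the first step that can be read at this position: a number 0.25 log units higher from compound 3 to compound 4 (within the scatter). A group of four carbon atoms gives way to a single fluorine atom and the result stays inside the scatter, so this change in the count of heavy atoms does not separate the two compounds. Nothing measured bears on why the two results lie so close.

Going by these compounds, whether an amine, a carboxylic acid or a longer chain at this place would move the number beyond the scatter remains open. For the compounds shown here, with only this one step to read, it also remains open whether the same exchange would give a similar step at any other place on the ring.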